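Fluoro on the benzamido arm: expected step for compound 4

The source may hold more compounds than are shown below. What is called first, only, known or untested is meant among the compounds shown, and "the series" means these compounds.

Measured so far in a functional assay on A549 cells (Homo sapiens) for antiproliferative activity, read by MTT assay; a higher number here means a weaker inhibitor, a lower number a stronger inhibitor:
compound 1, `COc1cc2c(Oc3ccc(NC(=O)N/N=C/c4ccccc4)cc3)ccnc2cc1OCCCCCCC(=O)NO`, gives 3700 nM;
compound 2, `COc1cc2c(Oc3ccc(NC(=O)N/N=C/c4ccc(F)cc4)cc3)ccnc2cc1OCCCCCCC(=O)NO`, gives 4920 nM;
compound 3, `COc1cc2c(Oc3ccc(NC(=O)NNC(=O)c4ccccc4)cc3)ccnc2cc1OCCCCCCC(=O)NO`, gives 2820 nM.

Compound 3 differs from compound 1 by a group of 9 heavy atoms (7 carbon, 1 nitrogen, 1 oxygen; one six-membered aromatic ring of carbon only) in place of a group of 8 heavy atoms (7 carbon, 1 nitrogen; one six-membered aromatic ring of carbon only), on an amide-type nitrogen; this gives a 1.3-fold lower number from compound 1 to compound 3 (0.12 log units; within the scatter), and against compound 2 the step is a 1.7-fold lower number from compound 2 to compound 3 (0.24 log units; within the scatter). The three numbers lie within the scatter of one another, so no order among them is claimed.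

Compound 4, `COc1cc2c(Oc3ccc(NC(=O)NNC(=O)c4ccccc4F)cc3)ccnc2cc1OCCCCCCC(=O)NO`, is not yet measured. It differs from compound 3 by fluoro in place of hydrogen on an aromatic carbon. The same change, (fluoro in place of hydrogen on an aromatic carbon), made a 1.3-fold higher number from compound 1 to compound 2 (0.12 log units; within the scatter). Going by the values given here, the two places are not identical: in compound 2 the fluoro sits para to a large group, in compound 4 ortho to a large group, so this is the same kind of change rather than the same change, and the one earlier case is the only precedent.

Among the compounds with values here, the step from compound 3 to compound 4 is expected to be a 1.2-fold higher number from compound 3 to compound 4 (0.09 log units; within the scatter), resting on the single earlier step of a 1.3-fold higher number from compound 1 to compound 2 (0.12 log units; within the scatter) and staying within the scatter. Compound 4 is therefore estimated at 3500 nM, between 1700 nM and 7500 nM.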

Compound 4, half-maximal inhibitory concentration: 2420 nM
Compound 4: middle estimate off by 1.4-fold (0.16 log units), on the high side; the measured number falls inside the stated range.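

In this assay, fluoro in place of hydrogen gives a 1.2-fold lower number from compound 3 to compound 4 (0.07 log units; within the scatter), and this step does not differ from the earlier one: the same change on two cores in this assay, a 1.3-fold higher number (0.12 log units; within the scatter) from compound 1 to compound 2 and a 1.2-fold lower number (0.07 log units; within the scatter) from compound 3 to compound 4, 1.5-fold (0.19 log units) apart, within the scatter of two such steps. The change therefore carries from the core of compound 1 to the core of compound 3 without a step beyond the scatter on either, but two small steps do not show that it has no effect in general, and the two cases differ in both core and the place of the fluoro, which cannot be separated here. Going by these compounds alone, the only step beyond the scatter is a 2.0-fold lower number from compound 2 to compound 4 (0.31 log units; beyond the scatter), while a 1.5-fold lower number from compound 1 to compound 4 (0.18 log units; within the scatter) stays within it, so these steps give no general ranking of the two arms.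

As far as these compounds go, whether a chloro, methoxy or amine group on the same phenyl ring would give a step beyond the scatter remains open. Also open, from the compounds shown here alone, is how a shorter or longer chain carrying the hydroxamic acid would read in this assay.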